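The compounds below may be only part of what the source reports. "The series", "measured", "known", "first", "only" and "open" are said of these compounds alone.

Measured in an ADME assay on Caco-2 cells (Homo sapiens) for permeability, read by LC-MS, in the apical to basolateral direction, with a stated time of 60 min, at pH 6.5; on this read-out lower numbers stand for lower permeability and higher numbers for higher permeability:
- Compound 1 `O=C(NCc1cc(Cl)ccc1-n1cnnn1)[C@@H]1C[C@@H]2C[C@@H]2N1C(=O)[C@H](O)Cn1cccn1`: 0.45 10^-6 cm/s
- Compound 2 `O=C(O[C@@H](C(=O)N1N=CC[C@H]1C(=O)NCc1cc(Cl)ccc1-n1cnnn1)c1ccc(F)cc1)c1ccccc1`: 43 10^-6 cm/s
- Compound 3 `O=C(NCc1cc(Cl)ccc1-n1cnnn1)[C@@H]1C[C@@H]2C[C@@H]2N1C(=O)[C@H](O)C1CCCCC1`: 16 10^-6 cm/s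

Compound 3 stands in the middle of these three numbers. Compound 2 lies somewhat higher, while compound 1 lies far lower.

Compound 4 `CC(C)(C)C[C@@H](O)C(=O)N1[C@H](C(=O)NCc2cc(Cl)ccc2-n2cnnn2)C[C@@H]2C[C@@H]21` has not yet been measured. It keeps the core of compound 3 and alters one group: neopentyl in place of cyclohexyl on a saturated chain carbon bound to a carbonyl carbon and an oxygen on a saturated carbon. In words, neopentyl sits in place of cyclohexyl on a saturated chain carbon bound to a carbonyl carbon and an oxygen on a saturated carbon.

Within the data shown here, one measured step bears on this place: a 36-fold higher number from compound 1 to compound 3 (1.55 log units; beyond the scatter). There, cyclohexyl replaced (1H-pyrazol-1-yl)methyl, and the change in the number was large. That step swapped a group containing nitrogen for one of carbon only. The new change is different in kind, since the group leaving and the group entering are both carbon only. Among the measured compounds shown here, no measured step shows such a swap, so this remains a judgement, and a small change seems the likeliest outcome.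

The expected step is a 1.2-fold lower number from compound 3 to compound 4 (0.09 log units; within the scatter), which would not stand clearly beyond the scatter. Starting from compound 3 at 16 10^-6 cm/s, the estimate for compound 4 is 13 10^-6 cm/s, with an expected range from 6 10^-6 cm/s to 26 10^-6 cm/s.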

Compound 4, apparent permeability: 25 10^-6 cm/s
Estimate against measurement, compound 4: 1.9-fold (0.28 log units) below, and the stated range covers the measured number.
By their numbers in this assay, from the lowest: compound 1; then compounds 3, 4 and 2 (each within the scatter of the next, the first and the last beyond it).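

In this assay, replacing one all-carbon group with another gives a 1.6-fold higher number from compound 3 to compound 4 (0.19 log units; within the scatter), so at this position the ringless neopentyl group and the six-membered carbon ring of cyclohexyl cannot be told apart, despite differing by one heavy atom. The large gap seen earlier also returns with a second all-carbon group, as the change from 1H-pyrazol-1-yl to tert-butyl on a saturated chain carbon, two bonds along the chain from a carbonyl carbon and an oxygen on a saturated carbon, gives a 56-fold higher number from compound 1 to compound 4 (1.74 log units; beyond the scatter) and places both carbon-only compounds well clear of compound 1. No supporting measurement is available to explain either result.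

With only these groups at this position, the compounds cannot show whether the high numbers depend on a carbon-only group or only on the absence of the nitrogen-containing 1H-pyrazol-1-yl group. A primary amine or a carboxylic acid at this position, or a short chain such as ethyl, would test how far that reading holds.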